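This account rests on a few compounds, and the source may have more. Where it says the series, first, only, none or still open, it means among the compounds named here.

In a functional assay on JAM cells (Homo sapiens) for antiproliferative activity (a higher number here means a weaker inhibitor, a lower number a stronger inhibitor), compound 1 `O=C(CCCCC[C@H](NC(=O)c1ccc(Br)cc1)C(=O)Nc1ccc(-c2ccccc2)cc1)NO` gives 182 nM while compound 2 `O=C(/C=C/c1ccccc1)N[C@@H](CCCCCC(=O)NO)C(=O)Nc1cccc2cccnc12` gives 49 nM as the lower of the two numbers. That gap lies beyond the usual scatter of repeated measurements, so compound 2 is the stronger inhibitor of this pair.

Among the measured compounds shown here, compound 3 `CC(C)COC(=O)N[C@@H](CCCCCC(=O)NO)C(=O)Nc1cccc2cccnc12`, which has no measurement yet, changes one place of compound 2: isobutoxy in place of 2-phenylethenyl on a carbonyl carbon. Cut one bond further out, the same change turns (2-phenylethenyl)carbonyl into isobutoxycarbonyl. The group that leaves holds a six-membered aromatic ring and a double bond outside it, whereas the group that enters has no ring.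

For the measured compounds named here, no measured pair shows this exchange on its own, so any expectation here is loose and the range must stay wide. Going by the values given here, a moderate weakening is expected, meaning a higher number in this assay than the one for compound 2, and the estimated change a 2.2-fold higher number from compound 2 to compound 3 (0.35 log units; beyond the scatter) only modestly clears the scatter. For compound 3 the estimated value is 110 nM with an expected range from 35 nM to 350 nM.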

Compound 3, half-maximal inhibitory concentration: 221 nM
Compound 3: middle estimate off by 2.0-fold (0.30 log units), on the low side, within the range that was stated.
By their numbers in this assay, from the lowest: compound 2; then compounds 1 and 3 (each within the scatter of the next).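

Exchanging 2-phenylethenyl for isobutoxy on a carbonyl carbon, with the rest of the molecule unchanged, gives a 4.5-fold higher number from compound 2 to compound 3 (0.65 log units; beyond the scatter) in this assay. The first two compounds differ in more than one place, so they could not tie a change in the number to any single group; this step shows that the group at this position alone can move the result by more than the scatter, and that here the group with the six-membered aromatic ring goes with the lower number. Nothing shown here explains why the number rises, so the step records an effect and not its cause.

This single exchange removes the aromatic ring and the double bond outside it and also brings in an oxygen, so the step cannot say which of these differences matters. A 2-phenylethyl group, which keeps the ring without the double bond, or a benzyloxy group, which pairs the ring with the oxygen, would be needed to pull these apart.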